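A few compounds are considered here, and "the series" means these few. Any claim that something is new, unique, unknown or untested is made for them only; others in the source may bear on it.

Compound 1 `O=C1NC(=O)/C(=C/c2ccccc2OCN2C(=O)c3ccccc3C2=O)S1` stands at the limit of an assay on isolated protein for inhibition of Alpha glucosidase (Homo sapiens), read by spectrophotometry, with stated times of 15 min and 30 min; a higher number here means a weaker inhibitor, a lower number a stronger inhibitor: in this assay compound 1 gives only > 100000 nM, a limit rather than a number. Compound 2 `COc1cccc(/C=C2\SC(=O)NC2=O)c1OCN1C(=O)c2ccccc2C1=O` likewise gives only a limit, > 100000 nM. The step that the two limits leave unreadable from compound 1 to compound 2 is thus unreadable, as both values sit at the limit of > 100000 nM in this assay, at which 2 of the 2 values shown sit. Compound 3 `O=C1NC(=O)/C(=C/c2cc([N+](=O)[O-])ccc2OCN2C(=O)c3ccccc3C2=O)S1` differs from compound 1 by nitro in place of hydrogen on an aromatic carbon. Within the data shown here, no measured step bears on this change, and the single measured step gives no size. Compound 3 is therefore expected to remain at the limit, the step of a number no higher from compound 1 to compound 3 (the limit leaves the size open) being of no readable size. The estimate for compound 3 is 100000 nM, within 30000 nM to 300000 nM.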

Compound 3, half-maximal inhibitory concentration: 50500 nM
Compound 3: the middle estimate sits 2.0-fold (0.30 log units) above what was measured; measured number inside the range.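

In this assay, compound 3 is the only compound shown that gives a number rather than a limit, 50500 nM. Nitro in place of hydrogen on this aromatic carbon, para to a large group, gives an at least 1.9-fold lower number from compound 1 to compound 3 (0.29 log units; that floor lies within the scatter), so its true size may be larger, but the readable part does not pass the scatter. Compound 1 and compound 2 remain at a limit: the limit of > 100000 nM in this assay, at which 2 of the 3 values shown sit.

From the compounds shown here alone, whether an amine or a carboxylic acid at this position would also give a number remains open. So does the effect of nitro on the core of compound 2.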